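Pyridin-4-yl replaces oxolanylmethyl on the piperazine nitrogen

This account rests on a few compounds, and the source may have more. Where it says the series, first, only, none or still open, it means among the compounds named here.

Measured compounds:
compound 1 `CCCCN1CCN(CCC(=O)Nc2nc3c(C)cccc3s2)CC1` — in an assay on HEK293 cells for antagonist activity at P2X purinoceptor 7 (Homo sapiens), read by fluorescence, with stated times of 30 min and 120 min (a lower number here means a stronger inhibitor, a higher number a weaker inhibitor), compound 1 gives no result reported
compound 2 `Cc1cccc2sc(NC(=O)CCN3CCN(CCN(C)C)CC3)nc12` — in this assay compound 2 gives 2150 nM
compound 3 `Cc1cccc2sc(NC(=O)CCN3CCN(CC4CCCO4)CC3)nc12` — in this assay compound 3 gives no result reported

Compound 3 stands without a number: the assay returned nothing for it that can be written as a single value, and the same is true of compound 1. Among the three compounds sharing the core of compound 3, only compound 2 carries a figure, and that figure alone marks the potency range this series has shown so far.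

Compound 4 `Cc1cccc2sc(NC(=O)CCN3CCN(c4ccncc4)CC3)nc12` follows from compound 3 by one change: pyridin-4-yl in place of (oxolan-2-yl)methyl on an amine nitrogen in a ring

Among the measured compounds shown here, no step between two measured compounds exists in this set, so there is nothing to show how a change at this ring nitrogen moves the number in this assay. The step from compound 3 to compound 4 is therefore expected to be one of no clear size or direction beyond the usual scatter, with the value of compound 2 as the only anchor.

Compound 4 is estimated at 2000 nM, with a range from 400 nM to 10000 nM.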

Compound 4, half-maximal inhibitory concentration: 1130 nM
Estimate against measurement, compound 4: 1.8-fold (0.25 log units) above; measured number inside the range.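

Among the compounds shown here, compound 4 gives this position a second number in this assay, and with it the first readable step at this ring nitrogen: a 1.9-fold lower number from compound 2 to compound 4 (0.28 log units; within the scatter). Pyridin-4-yl and 2-(dimethylamino)ethyl, an aromatic ring and an open chain, thus give readings within the usual scatter of each other when placed on this amine nitrogen in a ring. Steps involving compound 1 or compound 3 cannot be read, and nothing measured on these compounds accounts for the result.

As far as these compounds go, it remains open whether a pyridin-3-yl, a phenyl or a carboxylic acid on a longer chain at this nitrogen would move the number beyond the scatter. Also open, from the compounds shown here alone, is how the (oxolan-2-yl)methyl of compound 3 compares with these two groups.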